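Thiophene for Furan on a Dimethylamino Nucleoside

This account rests on a few compounds, and the source may have more. Where it says the series, first, only, none or still open, it means among the compounds named here.

Compound 2 `CN(C)c1ncnc2c1c(-c1ccoc1)cn2[C@@H]1O[C@H](CO)[C@@H](O)[C@H]1O` carries a dimethylamino group on the shared core. In a functional assay on A549 cells (Homo sapiens), read by MTT assay, with a stated time of 72 h (on this read-out higher numbers stand for weaker inhibition and lower numbers for stronger inhibition), compound 2 gives only > 20000 nM, which is a limit of the assay and not a number. Compound 1 `COc1ncnc2c1c(-c1ccoc1)cn2[C@@H]1O[C@H](CO)[C@@H](O)[C@H]1O` bears a methoxy group in the same place, and in this assay compound 1 gives 1160 nM. Compound 3 `Cc1ncnc2c1c(-c1ccoc1)cn2[C@@H]1O[C@H](CO)[C@@H](O)[C@H]1O` carries a methyl there, and in this assay compound 3 gives > 20000 nM, again a limit. The measured steps are an at least 17-fold higher number from compound 1 to compound 2 (1.23 log units; beyond the scatter) and an at least 17-fold higher number from compound 1 to compound 3 (1.23 log units; beyond the scatter); the step that the two limits leave unreadable from compound 2 to compound 3 cannot be read because both of its values sit at the limit of > 20000 nM in this assay, at which 2 of the 3 values shown sit.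

Compound 4 `CN(C)c1ncnc2c1c(-c1cccs1)cn2[C@@H]1O[C@H](CO)[C@@H](O)[C@H]1O` keeps the dimethylamino and differs from compound 2 in one place: thiophen-2-yl in place of furan-3-yl on an aromatic carbon. For the measured compounds named here, none of the measured steps touches the five-membered ring on the core; all three concern the group on the other aromatic carbon, so no measured step bears on this change. With compound 2 already at a limit, the expected step is a step that the limit leaves unreadable from compound 2 to compound 4, which means no change beyond the scatter. The estimate for compound 4 in this assay is 25000 nM, expected to lie between 8000 nM and 80000 nM, and a further limit rather than a number is quite likely.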

Compound 4, half-maximal inhibitory concentration: > 20000 nM
Compound 4 was reported as a limit (the forecaster's own chance of this, stated with the estimate: 70%); the middle value does not contradict the limit.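

Compound 2 and compound 4 both give a limit of the assay and not a number in this assay, so no step between them can be read: the limit of > 20000 nM in this assay, at which 3 of the 4 values shown sit.

The compounds shown leave open whether thiophen-2-yl in place of furan-3-yl changes inhibition at all.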